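The source may report more compounds than this note shows. Statements on the series, on what has been measured and on what is new or still open speak of the compounds shown alone.

Measured in an ADME assay on Vero cells (Chlorocebus sabaeus) for inhibition, read by sulforhodamine B assay, with a stated time of 48 h; on this read-out lower numbers stand for stronger inhibition of growth and higher numbers for weaker inhibition of growth:
- compound 1 `O=C(NNC(=O)c1ccc2[nH]c(-c3ccc([N+](=O)[O-])o3)nc2c1)c1ccccc1`: 31.3 ug/mL
- compound 2 `COc1cccc(C(=O)NNC(=O)c2ccc3[nH]c(-c4ccc([N+](=O)[O-])o4)nc3c2)c1`: 31.3 ug/mL
- compound 3 `O=CNNC(=O)c1ccc2[nH]c(-c3ccc([N+](=O)[O-])o3)nc2c1`: 62.5 ug/mL

At 62.5 ug/mL, compound 3 sits within the scatter of both other compounds, so the three cannot be ranked. The next compound, compound 4 `O=C(O)c1ccc2[nH]c(-c3ccc([N+](=O)[O-])o3)nc2c1`, differs from compound 3 as follows: hydroxy in place of (formylamino)amino on a carbonyl carbon. In words, hydroxy takes the place of (formylamino)amino on a carbonyl carbon, which turns (formylamino)carbamoyl into carboxy.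

Going by the values given here, no measured step makes this exact swap, and no measured compound carries hydroxy there, so the evidence is indirect. The closest guides are steps that also replace a group on a carbonyl carbon: a 2.0-fold higher number from compound 1 to compound 3 (0.30 log units; within the scatter) and a 2.0-fold higher number from compound 2 to compound 3 (0.30 log units; within the scatter). A methoxy change elsewhere gave no change at the digits printed from compound 1 to compound 2 (within the scatter). All three stay within the scatter, so only a small shift in this assay is expected, in no firm direction. The estimate amounts to no change at the digits printed from compound 3 to compound 4 (within the scatter). For compound 4 the expected value is 62.5 ug/mL, with an estimated range of 25 ug/mL to 160 ug/mL.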

Compound 4, concentration for 50% growth inhibition: > 250 ug/mL
Compound 4 ended at the assay's limit (the forecaster's own chance of this, stated with the estimate: 10%); at least 4.0-fold (0.60 log units) between middle value and limit.
By their numbers in this assay, from the lowest: compounds 1, 2 and 3 (each within the scatter of the next). At a limit, above all of these: compound 4.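

Until now, swapping the group on this carbonyl carbon had moved nothing beyond the scatter, as compounds 1, 2 and 3 all stayed close together. Going by these compounds alone, replacing (formylamino)amino with hydroxy, which turns (formylamino)carbamoyl into carboxy, is the first change here to clear it, with an at least 4.0-fold higher number from compound 3 to compound 4 (0.60 log units; beyond the scatter). In this assay a higher number means weaker inhibition of growth, so this carbonyl carbon is a place where a change can count, and the value for compound 4 is a limit, not a number: the limit of > 250 ug/mL in this assay, at which 1 of the 4 values shown sits.

From the compounds shown here alone, the true value of compound 4 stays unknown, so the step has only a lower bound. Going by these compounds, it also remains open whether the shift belongs to the carboxy group itself or to the loss of the nitrogen-containing group, and a methyl ester or a primary amide on the same carbonyl carbon would help to separate the two.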